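Swapping acetyl for fluoro in a series of amides

The source may report more compounds than this note shows. Statements on the series, on what has been measured and on what is new or still open speak of the compounds shown alone.

Measured in a functional assay on HL-60 cells (Homo sapiens) for inhibition, read by MTT assay, with a stated time of 72 h (a lower number here means a stronger inhibitor, a higher number a weaker inhibitor), so far
compound 1 `Cc1nc(-c2ccc(F)cc2)c(C(=O)N2CCN(c3ccc(C(=O)C(C)C)cc3)CC2)o1` gives "not active" (no number reported)
compound 2 `CC(=O)c1ccc(N2CCN(C(=O)c3oc(C)nc3-c3ccccc3)CC2)cc1` gives "not active" (no number reported)
compound 3 `Cc1nc(-c2ccc(F)cc2)c(C(=O)N2CCN(c3cc(Cl)cc(Cl)c3)CC2)o1` gives 52.1 nM

In this assay compound 2 has no number to its name, only the verdict "not active" (no number reported), and compound 1 shares that result. Compound 4 (`Cc1nc(-c2ccccc2)c(C(=O)N2CCN(c3ccc(F)cc3)CC2)o1`) has not yet been measured. The change leading to it is fluoro in place of acetyl on an aromatic carbon, which puts fluoro in place of acetyl on an aromatic carbon.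

Only compound 3 (52.1 nM) gives a number, and it carries chloro groups rather than a ketone. Compound 1 ("not active" (no number reported)) and compound 2 ("not active" (no number reported)) both carry a ketone. Three compounds are thin support, and compound 3 also differs from compound 4 elsewhere. Even so, the expected step is towards stronger inhibition, from no measurable activity to a number. Its size cannot be stated, as compound 2 offers no starting value, and another inactive result remains possible. Compound 4 is estimated to lie near 300 nM with 40 nM to 2500 nM as the expected range.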

Compound 4, half-maximal inhibitory concentration: > 1000 nM
Compound 4 ended at the assay's limit; the forecaster's own chance of this, stated with the estimate: 35%; middle value at least 3.3-fold (0.52 log units) from the limit.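

Compound 4 gives > 1000 nM in this assay, which is a limit and not a number. For the compounds shown here, compound 2 has only the verdict "not active", and no step between compound 2 and compound 4 can be read. The compounds shown leave open whether fluoro in place of acetyl changes inhibition at all.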